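Swapping the anilide phenyl of compound 1 for a chloropyridyl

This account rests on a few compounds, and the source may have more. Where it says the series, first, only, none or still open, it means among the compounds named here.

Measured compounds:
- compound 1, `O=C(Nc1ccccc1)c1c(O)c2cccnc2n(-c2ccccc2)c1=O`: -15%
- compound 2, `O=C(Nc1ccc([N+](=O)[O-])cc1)c1c(O)c2cccnc2n(-c2ccccc2)c1=O`: -25.8%
- compound 3, `O=C(NCc1ccncc1)c1c(O)c2cccnc2n(-c2ccccc2)c1=O`: 15.4%

All three were tested in a functional assay on the whole organism for inhibition, with Rattus norvegicus as the target, read by cytopathic effect and paw edema, at a dose of 100 mg/kg by the oral route; a higher number here means more inhibition at the dose given (going by the name of the read-out), a lower number less inhibition. Among them compound 1 stands second highest: compound 2 lies nearest, and compound 3 furthest, both beyond the scatter. Two changes have been tried on the amide side of the shared core. Adding a nitro to the phenyl gave a number 10.8 percentage points lower from compound 1 to compound 2 (beyond the scatter), a modest lowering. Replacing the phenyl by a (pyridin-4-yl)methyl gave a number 30.4 percentage points higher from compound 1 to compound 3 (beyond the scatter), a large gain.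

Compound 4, `O=C(Nc1ccc(Cl)nc1)c1c(O)c2cccnc2n(-c2ccccc2)c1=O`, is not yet measured. It differs from compound 1 by 6-chloropyridin-3-yl in place of phenyl on an amide-type nitrogen. The change keeps an aromatic ring on the amide-type nitrogen, as in compound 2, yet brings in a ring nitrogen, as in compound 3. The two measured steps point in opposite directions, so in this assay no step beyond the scatter is confidently expected, with the wide range reflecting that uncertainty. Compound 4 is therefore estimated at -5%, between -30% and 20%, an expected step of a number 10 percentage points higher from compound 1 to compound 4 (within the scatter).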

Compound 4, a percentage reported as inhibition, in the whole organism at one dose (the size of the read-out at that dose, not a potency): -4%
Compound 4: middle estimate off by 1 percentage points, on the low side; the range from low to high includes it.
By their numbers in this assay, from the lowest: compound 2; then compound 1; then compound 4; then compound 3.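

In this assay, going by these compounds alone, a ring attached directly to the amide-type nitrogen is not tied to a lower number: 6-chloropyridin-3-yl gives a number 11 percentage points higher from compound 1 to compound 4 (beyond the scatter), whereas the only earlier change that kept such a ring, the 4-nitrophenyl, lowered it, and the two substituted rings stand apart by a number 21.8 percentage points higher from compound 2 to compound 4 (beyond the scatter). The gain still falls short of the (pyridin-4-yl)methyl group, with a number 19.4 percentage points lower from compound 3 to compound 4 (beyond the scatter), so that group remains the best of the four at this position. Nothing measured here explains these steps.

The new group brings in a ring nitrogen and a chlorine together, so a plain pyridin-3-yl and a 4-chlorophenyl would be needed to tell their shares apart. From the compounds shown here alone, whether the higher number of compound 3 rests on its ring nitrogen or its methylene link also stays open, and a benzyl group would address that.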